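The source may report more compounds than this note shows. Statements on the series, on what has been measured and on what is new or still open speak of the compounds shown alone.

Compound 1 `COc1ccc2[nH]c(C(=O)N3CC(=O)N(Cc4ccccc4)[C@@H](CCc4ccccc4)C3)cc2c1` is one of three compounds examined in an ADME assay on Vero cells (Chlorocebus sabaeus) for cytotoxicity, with a stated time of 7 days; a higher number here means that more compound is tolerated, a lower number that less compound is tolerated. In this assay compound 1 reaches only a limit, > 30000 nM. Compound 3 `COc1ccc2[nH]c(C(=O)N3CC(=O)N(Cc4ccccc4)[C@@H](N4CCC(Cc5ccccc5)CC4)C3)cc2c1` also stops at a limit in this assay, > 30000 nM. Compound 2 `COc1cccc(CN2C(=O)CN(C(=O)c3cc4cc(OC)ccc4[nH]3)C[C@@H]2Cc2ccccn2)c1` gives only a limit as well, > 10000 nM. Two of the three values rest at the limit of > 30000 nM in this assay, at which 2 of the 3 values shown sit, and one at the limit of > 10000 nM in this assay, at which 1 of the 3 values shown sits, so none of the three shows measurable cytotoxicity within its tested range. Compound 4 `COc1ccc2[nH]c(C(=O)N3CC(=O)N(Cc4ccccc4)[C@@H](COc4ccc(F)cc4)C3)cc2c1` has not yet been tested; it differs from compound 1 by 4-fluorophenoxy in place of benzyl on a saturated chain carbon bound to a saturated ring carbon. Within the data shown here, with no measured step between related compounds to draw on, the expected change in this assay, a number no higher from compound 1 to compound 4 (the limit leaves the size open), is none beyond the scatter. Compound 4 is expected to give 30000 nM, between 15000 nM and 60000 nM, most likely again as a limit.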

Compound 4, half-maximal cytotoxic concentration: 33200 nM
Compound 4: the middle estimate sits 1.1-fold (0.04 log units) below what was measured, and the stated range covers the measured number.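

Compound 1 gives only a limit, > 30000 nM. Among these compounds, no step from compound 1 to compound 4 can be read from it. The compounds shown leave open whether 4-fluorophenoxy in place of benzyl changes the tolerated concentration in this assay at all.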